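From 4-fluorophenyl to 4-fluorobenzyl on a sulfur

The source may report more compounds than this note shows. Statements on the series, on what has been measured and on what is new or still open speak of the compounds shown alone.

In a functional assay on DU-145 cells (Homo sapiens) for inhibition, read by trypan blue exclusion, with a stated time of 96 h (a higher number here means a weaker inhibitor of growth, a lower number a stronger inhibitor of growth), the measured compounds are
compound 1 `Cc1ccc(/C=C(/SCc2ccc(Cl)cc2Cl)C(=O)c2ccc(Cl)cc2)s1` with 50000 nM
compound 2 `Cc1ccc(CS/C(=C/c2ccc(C)s2)C(=O)c2ccc(Cl)cc2)cc1` with 50000 nM
compound 3 `Cc1ccc(/C=C(/Sc2ccc(F)cc2)C(=O)c2ccc(Cl)cc2)s1` with 25000 nM

Compound 3 is not separated from either of the others: the steps of a 2.0-fold lower number from compound 1 to compound 3 (0.30 log units; within the scatter) and a 2.0-fold lower number from compound 2 to compound 3 (0.30 log units; within the scatter) both lie within the scatter. Compound 4 `Cc1ccc(/C=C(/SCc2ccc(F)cc2)C(=O)c2ccc(Cl)cc2)s1` carries 4-fluorobenzyl in place of 4-fluorophenyl on a sulfur and is otherwise the same as compound 3.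

Those two steps bear most directly on this change, since each replaces a substituted benzyl on the sulfur with 4-fluorophenyl, the reverse of the exchange made here. The step of no change at the digits printed from compound 1 to compound 2 (within the scatter), between two substituted benzyl groups, also stays within the scatter. The three measured compounds therefore give no ground for expecting a change beyond the scatter, although the two with a benzyl on the sulfur suggest a slightly higher number, if any. The expected step is a 1.6-fold higher number from compound 3 to compound 4 (0.20 log units; within the scatter) (within the scatter). In this assay compound 4 is estimated at 40000 nM (expected range 15000 nM to 70000 nM).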

Compound 4, concentration for 50% growth inhibition: > 100000 nM
Compound 4 gave a limit, no number; the forecaster's own chance of this, stated with the estimate: 25%; middle value at least 2.5-fold (0.39 log units) away from the limit.
By their numbers in this assay, from the lowest: compounds 3, 1 and 2 (each within the scatter of the next). At a limit, above all of these: compound 4.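

In this assay, compound 4 gives a limit and not a number: the limit of > 100000 nM in this assay, at which 1 of the 4 values shown sits. Even so, placing 4-fluorobenzyl in place of 4-fluorophenyl on this sulfur produces the first step in the series to pass the scatter, an at least 4.0-fold higher number from compound 3 to compound 4 (0.60 log units; beyond the scatter), so this position can register a change of this kind, which the earlier steps could not show. The steps to compound 4 from the other two benzyl compounds, an at least 2.0-fold higher number from compound 2 to compound 4 (0.30 log units; that floor lies within the scatter) and an at least 2.0-fold higher number from compound 1 to compound 4 (0.30 log units; that floor lies within the scatter), have floors within the scatter, so the limit does not show whether 4-fluorobenzyl differs from those groups.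

The compounds shown leave open how far the true value of compound 4 lies past its limit. They also leave open whether a longer chain such as 2-(4-fluorophenyl)ethyl on the sulfur would continue this step, or whether 2,4-dichlorophenyl there would match 4-fluorophenyl.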